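A few compounds are considered here, and "the series" means these few. Any claim that something is new, unique, unknown or untested is made for them only; others in the source may bear on it.

Compound 1 `O=C(COc1ccc(Cl)cc1)Nc1nc(-c2ccc(Br)cc2)cs1` is the starting point. In a functional assay on MCF7 cells (Homo sapiens) for cytotoxicity, read by trypan blue exclusion, with a stated time of 48 h (on this read-out lower numbers stand for stronger inhibition and higher numbers for weaker inhibition), compound 1 gives 41400 nM. Compound 2 `Cc1cc(OCC(=O)Nc2nc(-c3ccc(Br)cc3)cs2)ccc1Cl` differs from it by one change, (methyl in place of hydrogen on an aromatic carbon), and in this assay compound 2 gives 51700 nM; the step is a 1.2-fold higher number from compound 1 to compound 2 (0.10 log units; within the scatter). Compound 3 `O=C(COc1ccccc1)Nc1nc(-c2ccc(Cl)cc2)cs1` carries a different core, and the difference between the two cores is not broken down here. In this assay compound 3 gives 55900 nM, a number that sits close to those of compound 1 and compound 2.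

Compound 4 `Cc1ccccc1OCC(=O)Nc1nc(-c2ccc(Cl)cc2)cs1` is not yet measured. It arises from compound 3 by methyl in place of hydrogen on an aromatic carbon. For the measured compounds named here, this is the same kind of change as the one from compound 1 to compound 2, but the surroundings differ: in compound 4 the methyl sits ortho to a large group, whereas in compound 2 it sits ortho to a chloro group and meta to a large group. Because the earlier step of a 1.2-fold higher number from compound 1 to compound 2 (0.10 log units; within the scatter) hardly moved the number, the step from compound 3 to compound 4 is expected to be similarly small, a 1.1-fold higher number from compound 3 to compound 4 (0.04 log units; within the scatter). Compound 4 is therefore estimated at 62000 nM in this assay, likely between 30000 nM and 130000 nM.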

Compound 4, half-maximal inhibitory concentration: 62800 nM
Compound 4: the middle estimate sits 1.0-fold (0.01 log units) below what was measured; measured number inside the range.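

In this assay, methyl in place of hydrogen on an aromatic carbon gives a 1.1-fold higher number from compound 3 to compound 4 (0.05 log units; within the scatter), so this change again leaves the number where it was, now with the methyl ortho to a large group. On the two cores shown, the change therefore behaves alike: the same change on two cores in this assay, a 1.2-fold higher number (0.10 log units; within the scatter) from compound 1 to compound 2 and a 1.1-fold higher number (0.05 log units; within the scatter) from compound 3 to compound 4, 1.1-fold (0.05 log units) apart, within the scatter of two such steps. This supports carrying the estimate for this change from one of these cores to the other, but both steps are so small that they cannot separate a slight real effect from none, and two cores say nothing firm about other cores in the series.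

The compounds shown leave open whether a group other than methyl at this spot, such as an amine or a carboxylic acid, would move the number further. They also leave open whether a longer chain in place of the methyl, or a longer link between the phenoxy ring and the amide, would change the number on either core.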